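The source may hold more compounds than are shown below. What is called first, only, known or untested is meant among the compounds shown, and "the series" means these compounds.

In a functional assay (Homo sapiens) for antiproliferative activity (on this read-out lower numbers stand for stronger inhibition of growth and higher numbers for weaker inhibition of growth), compound 1 (`N=C(N)N/N=C/c1c(-c2cc([N+](=O)[O-])c(Cl)cc2Cl)nc2sc(Cl)cn12`) gives 3550 nM and compound 2 (`N=C(N)N/N=C/c1c(-c2ccccn2)nc2sc(Cl)cn12`) gives 4370 nM, so compound 2 stands within the scatter of compound 1. Compound 3 (`N=C(N)N/N=C/c1c(-c2ccncc2)nc2sc(Cl)cn12`) carries pyridin-4-yl in place of pyridin-2-yl on an aromatic carbon. For the measured compounds named here, no step between measured compounds bears on this change, so no shift beyond the scatter is expected in this assay, with only a slight lean toward stronger inhibition (estimated step a 1.5-fold lower number from compound 2 to compound 3 (0.16 log units; within the scatter)). For compound 3 the estimated value is 3000 nM (expected range 1200 nM to 7500 nM).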

Compound 3, concentration for 50% growth inhibition: 3800 nM
Estimate against measurement, compound 3: 1.3-fold (0.10 log units) below; the range from low to high includes it.
By their numbers in this assay, from the lowest: compounds 1, 3 and 2 (each within the scatter of the next).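

In this assay, pyridin-4-yl in place of pyridin-2-yl on this aromatic carbon gives a 1.2-fold lower number from compound 2 to compound 3 (0.06 log units; within the scatter), the first step readable at this position. The two groups have the same atoms and differ only in how they are joined, and on this read-out that difference stays within the scatter. No measured result on hand offers an explanation for this outcome.

Still open, on these data alone, is whether this carbon tolerates groups other than these pyridinyl rings. A saturated amine such as piperidin-1-yl, or a phenyl ring bearing a carboxylic acid, would test this.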